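Swapping 4-methoxyphenyl for 3-chlorophenyl on the shared core

This account rests on a few compounds, and the source may have more. Where it says the series, first, only, none or still open, it means among the compounds named here.

In a toxicity assay on HEK-293T cells (Homo sapiens) for inhibition, read by MTT assay, with a stated time of 24 h (on this read-out lower numbers stand for higher toxicity in this test and higher numbers for lower toxicity in this test), compound 1 (`O=c1oc2ccccc2c(N2CCN(c3cccc(Cl)c3Cl)CC2)c1CO`) gives > 50000 nM, which is a limit and not a number. Compound 2 (`COc1ccc(N2CCN(c3c(CO)c(=O)oc4ccccc34)CC2)cc1`) gives > 50000 nM, again only a limit. Both compounds therefore sit at the same limit: the limit of > 50000 nM in this assay, at which 2 of the 2 values shown sit. Compound 3 (`O=c1oc2ccccc2c(N2CCN(c3cccc(Cl)c3)CC2)c1CO`) has 3-chlorophenyl in place of 4-methoxyphenyl on an amine nitrogen in a ring. Among the measured compounds shown here, the only measured step bearing on this change, a step that the two limits leave unreadable from compound 1 to compound 2, gives no size, so no change beyond the scatter is expected. In this assay, the expected step is a number no higher from compound 2 to compound 3 (the limit leaves the size open). Compound 3 is expected at 50000 nM, with an estimated range of 25000 nM to 100000 nM.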

Compound 3, half-maximal cytotoxic concentration: > 50000 nM
Compound 3 was reported as a limit; the forecaster's own chance of this, stated with the estimate: 85%; the middle value lies on the limit itself.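

No step can be read among compound 1, compound 2 and compound 3, as all three values are limits and not numbers: the limit of > 50000 nM in this assay, at which 3 of the 3 values shown sit. The compounds shown leave open whether their aromatic groups on the shared core differ at all in this assay.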